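The compounds below may be only part of what the source reports. "The series", "measured", "known", "first", "only" and "open" are said of these compounds alone.

Measured so far in a physicochemical assay for lipophilicity, using the shake flask method, in phosphate buffer, measured as octanol-water partition, with a stated time of 30 min, at pH 7.4 (a higher number here means a more lipophilic compound, a lower number a more polar compound), for the series:

- compound 1 `CN(c1ccn(C)n1)c1cnc(NCc2c(F)ccc3c2CCO3)n2cnnc12` gives 1.8
- compound 2 `CN(c1cccnc1)c1cnc(NCc2c(F)ccc3c2CCO3)n2cnnc12` gives 2.6

Compound 2 stands highest of the two measured compounds at 2.6 and its gap to compound 1 lies beyond the scatter. The next step leads to compound 3 `Fc1ccc2c(c1CNc1ncc(Nc3ccccc3)c3nncn13)CCO2` with anilino in place of methyl(pyridin-3-yl)amino on an aromatic carbon and the shared core unchanged.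

For the measured compounds named here, no measured step covers this exact exchange. The nearest evidence is a number 0.80 log units higher from compound 1 to compound 2 (beyond the scatter) with pyridin-3-yl in place of 1-methyl-1H-pyrazol-3-yl on a nitrogen on an aromatic ring, a modest step. Here the ring again changes, now to one of carbon only, and the methyl leaves too. The two parts of this change cannot be separated with the data in hand, so the estimate is loose. A modest upward move is expected, estimated as a number 0.50 log units higher from compound 2 to compound 3 (beyond the scatter) in this assay. The estimate for compound 3 is 3.1 with an expected range of 2.6 to 3.6 in this measurement.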

Compound 3, distribution coefficient: 3.3
For compound 3 the middle estimate is 0.20 log units below the measured one; the range from low to high includes it.
By their numbers in this assay, from the lowest: compound 1; then compound 2; then compound 3.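

For the compounds shown here, at this aromatic carbon in this assay, anilino in place of methyl(pyridin-3-yl)amino gives a number 0.70 log units higher from compound 2 to compound 3 (beyond the scatter) and so extends the upward trend beyond the first exchange of ring on the nitrogen. Across the three compounds, the order runs from the methyl(1-methyl-1H-pyrazol-3-yl)amino group through methyl(pyridin-3-yl)amino to anilino, and the full exchange gives a number 1.50 log units higher from compound 1 to compound 3 (beyond the scatter) as the largest step shown, with no compound here going against that order. The anilino step changes the ring to one of carbon only and also removes the methyl, and no measurement available here explains the rise or assigns it to either part.

Open, going by these compounds, is where methyl(phenyl)amino would stand, since this group would keep the methyl on the nitrogen with the carbon-only ring and so separate the two parts of the step from compound 2 to compound 3. Also open is how far the reading at this position would move with a carboxylic acid or a dimethylamino group on the phenyl ring of anilino, as the compounds shown carry no substituent there.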